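A few compounds are considered here, and "the series" means these few. Any claim that something is new, unique, unknown or untested is made for them only; others in the source may bear on it.

Of the compounds shown here, two with a shared core have been measured in an ADME assay on microsomes from liver (Homo sapiens) for metabolic stability, read by LC-MS, with NADPH named in the record, with a stated time of 60 min, tested at 1 uM, in the absence of a further agent; on this read-out higher numbers stand for a more stable compound and lower numbers for a less stable compound: compound 1, `COc1ccc(-n2c(C)nc3c(N4CC[C@@H](NC(C)=O)C4)nc(C)nc32)cc1OC`, and compound 2, `COc1ccc(-c2c(C)nc3c(N4CC[C@@H](NS(C)(=O)=O)C4)cc(C)nn23)cc1OC`. In this assay compound 1 sits at the assay's limit, > 95%, which is a limit and not a number. In this assay compound 2 likewise sits at the assay's limit, > 95%, again a limit rather than a number. Compound 2 therefore stands where every value shown stands, because of the limit of > 95% in this assay, at which 2 of the 2 values shown sit, so the two compounds cannot be ordered against each other.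

Compound 3, `COc1ccc(-c2c(C)nc3c(N4CC[C@@H](NS(=O)(=O)c5ccc(C#N)cc5)C4)cc(C)nn23)cc1OC`, is yet to be measured in this assay. It differs from compound 2 in one place: 4-cyanophenyl in place of methyl on a sulfonyl sulfur. No step between measured compounds is shown, so the size of this change is uncertain. Compound 3 is expected to give 82%, between 55% and 95%. That estimate means an expected step of a number at least 13 percentage points lower from compound 2 to compound 3 (beyond the scatter), a downward move of moderate size, beyond the usual scatter.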

Compound 3, percent of the compound remaining: > 95%
Compound 3 ended at the assay's limit; the forecaster's own chance of this, stated with the estimate: 35%; at least 13 percentage points between middle value and limit.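

No step can be read from compound 2 to compound 3 in this assay, since both compounds sit at a limit of the assay: the limit of > 95% in this assay, at which 3 of the 3 values shown sit.

The compounds shown leave open whether 4-cyanophenyl in place of methyl on a sulfonyl sulfur changes the percent of compound remaining, and in which direction.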